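Swapping the Amine Side Chain of Compound 3

A few compounds are considered here, and "the series" means these few. Any claim that something is new, unique, unknown or untested is made for them only; others in the source may bear on it.

Compound 3 `CCN(CC)CCn1cnnc1-c1cc(Oc2ccc(NC(=O)Nc3cccc(C(F)(F)F)c3)cc2F)ccn1` gives 630 nM in a functional assay on HT-29 cells (Homo sapiens) for antiproliferative activity, read by MTT assay, with a stated time of 72 h (a lower number here means a stronger inhibitor, a higher number a weaker inhibitor), the lowest number among the measured compounds. Compound 2 `Cn1cnnc1-c1cc(Oc2ccc(NC(=O)Nc3cccc(C(F)(F)F)c3)cc2F)ccn1` gives 3020 nM in this assay. For compound 1 `Cn1ncnc1-c1cc(Oc2ccc(NC(=O)Nc3cccc(C(F)(F)F)c3)cc2F)ccn1` this assay returns a limit, > 50000 nM (the limit of > 50000 nM in this assay, at which 1 of the 3 values shown sits). The steps of an at least 16-fold lower number from compound 1 to compound 2 (1.21 log units; beyond the scatter) and an at least 79-fold lower number from compound 1 to compound 3 (1.89 log units; beyond the scatter) are large, while the step of a 4.8-fold lower number from compound 2 to compound 3 (0.68 log units; beyond the scatter) is modest and bears most directly on compound 4 `CN(C)CCCn1cnnc1-c1cc(Oc2ccc(NC(=O)Nc3cccc(C(F)(F)F)c3)cc2F)ccn1`, which differs from compound 3 by (dimethylamino)methyl in place of diethylamino on a saturated chain carbon, two bonds along the chain from an aromatic nitrogen. Both compounds carry an amine-bearing chain on the same ring nitrogen, so the step of a 1.1-fold higher number from compound 3 to compound 4 (0.05 log units; within the scatter) is expected to stay within the scatter, with no clear direction. Compound 4 is therefore estimated at 700 nM, with a range from 250 nM to 2000 nM.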

Compound 4, half-maximal inhibitory concentration: 980 nM
Beside the measured number, compound 4's estimate is 1.4-fold (0.15 log units) below it; measured number inside the range.
By their numbers in this assay, from the lowest: compounds 3 and 4 (each within the scatter of the next); then compound 2. At a limit, above all of these: compound 1.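

Replacing diethylamino with (dimethylamino)methyl leaves the result within the scatter, a 1.6-fold higher number from compound 3 to compound 4 (0.19 log units; within the scatter), so two differently built amine chains fit at this position. The gain over the methyl of compound 2 is therefore not confined to compound 3, as a 3.1-fold lower number from compound 2 to compound 4 (0.49 log units; beyond the scatter) shows. The step of an at least 51-fold lower number from compound 1 to compound 4 (1.70 log units; beyond the scatter) starts from a limit, not a number: the limit of > 50000 nM in this assay, at which 1 of the 4 values shown sits.

Chain length and the substituents on the amine change together here, so their separate contributions remain open. Also open, as far as these compounds go, is whether a morpholine, a piperidine or a chain ending in a carboxylic acid would match these amine chains.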